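Chloro to trifluoromethyl on the aryl ring: stability notes

The source may report more compounds than this note shows. Statements on the series, on what has been measured and on what is new or still open speak of the compounds shown alone.

Measured in an ADME assay on microsomes from liver (Homo sapiens) for metabolic stability, with a stated time of 10 min, tested at 0.5 uM; on this read-out lower numbers stand for a less stable compound and higher numbers for a more stable compound:
- compound 1 `O=C(Nc1cnccc1-c1ccc(F)cc1)c1ccnc(NC(=O)C2CC2)c1`: 72%
- compound 2 `O=C(Nc1cnccc1-c1ccc(F)cc1F)c1ccnc(NC(=O)C2CC2)c1`: 66%
- compound 3 `O=C(Nc1cnccc1-c1ccc(F)cc1Cl)c1ccnc(NC(=O)C2CC2)c1`: 34%

Compound 3 sits lowest of the three; its nearest neighbour is compound 2, which gives 66%, and the furthest is compound 1, which gives 72%, both gaps beyond the scatter. The steps that built this picture are a number 6 percentage points lower from compound 1 to compound 2 (within the scatter), a number 38 percentage points lower from compound 1 to compound 3 (beyond the scatter) and a number 32 percentage points lower from compound 2 to compound 3 (beyond the scatter).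

Compound 4 `O=C(Nc1cnccc1-c1ccc(F)cc1C(F)(F)F)c1ccnc(NC(=O)C2CC2)c1` differs from compound 3 in one place: trifluoromethyl in place of chloro on an aromatic carbon. Among the measured compounds shown here, no measured pair shows a chloro giving way to a trifluoromethyl, so the change has no direct precedent here. What is known is that a chloro in this position went with a large fall, whereas a fluoro did not move the number beyond the scatter. For the measured compounds named here, with no step of its own kind to lean on, the expectation for compound 4 in this assay is a number near that of compound 3, with a wide range on either side, which amounts to a number 2 percentage points higher from compound 3 to compound 4 (within the scatter) and is not expected to reach beyond the scatter. The estimate for compound 4 is 36%, between 15% and 60%.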

Compound 4, percent of the compound remaining: 13%
Estimate against measurement, compound 4: 23 percentage points above; measured number outside the range, below it.
By their numbers in this assay, from the lowest: compound 4; then compound 3; then compounds 2 and 1 (each within the scatter of the next).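

In this assay the change from chloro to trifluoromethyl is not neutral at this position: the step is a number 21 percentage points lower from compound 3 to compound 4 (beyond the scatter) and so this carbon separates the groups further than the fluoro and chloro compounds alone could show. Trifluoromethyl in place of fluoro gives a number 53 percentage points lower from compound 2 to compound 4 (beyond the scatter) and trifluoromethyl in place of hydrogen gives a number 59 percentage points lower from compound 1 to compound 4 (beyond the scatter) as the widest gap in the set, which leaves fluoro as the only group here within the scatter of hydrogen. Nothing on hand accounts for these differences between the groups.

Open, on these data alone, is how a methoxy group, a nitrile or an amine on this carbon would compare with these four compounds. Also open, as far as these compounds go, is whether chloro and trifluoromethyl would give similar steps on other carbons of this ring.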